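This account rests on a few compounds, and the source may have more. Where it says the series, first, only, none or still open, it means among the compounds named here.

Measured compounds in a functional assay on SK-N-SH cells (Homo sapiens) for inhibition, read by sulforhodamine B assay, with a stated time of 48 h; a lower number here means a stronger inhibitor, a higher number a weaker inhibitor:
compound 1 `CO[C@@H]1CC=C2NN(c3cc4ccccc4[nH]3)C(=O)C[C@]2(c2ccncc2)O1`: 3900 nM
compound 2 `COc1ccc(N2NC3=CC[C@@H](OC)O[C@@]3(c3ccccc3)CC2=O)cc1`: 10400 nM
compound 3 `CO[C@@H]1CC=C2NN(c3cncnc3)C(=O)C[C@]2(c2ccccc2)O1`: 8200 nM

Compound 3 has the second highest of these three numbers; compound 2 lies nearest, within the scatter, while compound 1 gives the lowest number. Compound 4 `CO[C@@H]1CC=C2NN(c3cc4ccccc4[nH]3)C(=O)C[C@]2(c2ccccc2)O1` differs from compound 3 in one place: 1H-indol-2-yl in place of pyrimidin-5-yl on an amide-type nitrogen in a ring. Among the measured compounds shown here, the one measured step at this position, a 1.3-fold lower number from compound 2 to compound 3 (0.10 log units; within the scatter), lay within the scatter and involved groups unlike the entering one, so it offers little guidance. Compound 1 also carries 1H-indol-2-yl at this position but differs from compound 3 in a second place too, so its value only hints at the size. On that basis compound 4 is expected to show a 2.1-fold lower number from compound 3 to compound 4 (0.31 log units; beyond the scatter) in this assay. The estimate for compound 4 is 4000 nM, with a range from 1500 nM to 10000 nM.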

Compound 4, half-maximal inhibitory concentration: 9100 nM
Compound 4: middle estimate off by 2.3-fold (0.36 log units), on the low side; the range from low to high includes it.
By their numbers in this assay, from the lowest: compound 1; then compounds 3, 4 and 2 (each within the scatter of the next).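

In this assay, the group on the amide-type nitrogen has made no clear difference so far: a 1.1-fold higher number from compound 3 to compound 4 (0.05 log units; within the scatter) and a 1.1-fold lower number from compound 2 to compound 4 (0.06 log units; within the scatter) leave pyrimidin-5-yl, 4-methoxyphenyl and 1H-indol-2-yl indistinguishable. Among the compounds shown here, the only step beyond the scatter lies on the saturated ring carbon, where phenyl replaces pyridin-4-yl: a 2.3-fold higher number from compound 1 to compound 4 (0.37 log units; beyond the scatter) shows that the lower number of compound 1 goes with pyridin-4-yl, not with 1H-indol-2-yl. Nothing available explains either result.

Still open, as far as these compounds go, is whether pyridin-4-yl has the same effect alongside other groups on the amide-type nitrogen. Also open, from the compounds shown here alone, is whether an amine or a carboxylic acid there would shift the number.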